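Oxime ether series: from a methyl to a chloro benzyl

The source may report more compounds than this note shows. Statements on the series, on what has been measured and on what is new or still open speak of the compounds shown alone.

Measured compounds:
compound 1 `O=[N+]([O-])c1ccc2c(c1)/C(=N\O)C(c1c[nH]c3ccc([N+](=O)[O-])cc13)=N2`: 11500 nM
compound 2 `Cc1ccc(CO/N=C2/C(c3c[nH]c4ccc(Br)cc34)=Nc3ccc(Br)cc32)cc1`: 10600 nM

In a functional assay on NCI-H460 cells (Homo sapiens) for cytotoxicity, read by MTT assay, with a stated time of 2 days (on this read-out higher numbers stand for weaker inhibition and lower numbers for stronger inhibition), compound 2 gives 10600 nM. Compound 1 gives 11500 nM in this assay; the two numbers lie within the usual scatter of each other, so neither can be placed ahead of the other. Compound 2 stands at the lower end of the two numbers shown, but only nominally.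

Compound 3 `Clc1cccc(CO/N=C2/C(c3c[nH]c4ccc(Br)cc34)=Nc3ccc(Br)cc32)c1` is not yet measured. It differs from compound 2 in one place: 3-chlorophenyl in place of 4-methylphenyl on a saturated chain carbon bound to an oxygen on an unsaturated carbon. Within the data shown here, no step between measured compounds covers a change of this kind, so there is nothing to scale an expectation from. The estimate for compound 3 in this assay is therefore taken close to compound 2, with the step of a 1.1-fold lower number from compound 2 to compound 3 (0.03 log units; within the scatter) expected to stay within the scatter in either direction. Compound 3 is expected to give about 10000 nM, with a range of 4000 nM to 25000 nM.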

Compound 3, half-maximal inhibitory concentration: 14600 nM
Compound 3: the middle estimate sits 1.5-fold (0.16 log units) below what was measured, within the range that was stated.
By their numbers in this assay, from the lowest: compounds 2, 1 and 3 (each within the scatter of the next).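

In this assay, 3-chlorophenyl in place of 4-methylphenyl on a saturated chain carbon bound to an oxygen on an unsaturated carbon gives a 1.4-fold higher number from compound 2 to compound 3 (0.14 log units; within the scatter) and so leaves no readable difference between compound 2 and compound 3. Among these compounds, this is the first step read at this position, and it shows that this exchange of one substituted phenyl group for another, with the rest of the structure held constant, does not move the number beyond the scatter. No supporting measurement bears on the reason for this result.

The step changes both the substituent and its printed ring position, so the compounds shown cannot separate these two parts; 4-chlorophenyl or 3-methylphenyl would do so. On these data alone, it also remains open whether a carboxylic acid, an amine or a longer chain at this position would give a step beyond the scatter.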